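The source may report more compounds than this note shows. Statements on the series, on what has been measured and on what is new or still open speak of the compounds shown alone.

Measured so far in a physicochemical assay for lipophilicity, read by HPLC, in phosphate buffer, measured as chromatographic lipophilicity, at pH 7.4; a higher number here means a more lipophilic compound, a lower number a more polar compound:
Compound 1 `CCOc1ccc2nc(C(F)(F)F)cc(OCC(=O)Nc3cc(C)cc(C)c3)c2c1` gives 7.55.
Compound 2 `COc1ccc2nc(C)cc(OCC(=O)Nc3cccc(C)c3)c2c1` gives 4.83.
Compound 3 `COc1ccc2nc(C)cc(OCC(=O)Nc3cc(OC)c(OC)c(OC)c3)c2c1` gives 3.95.

Compound 2 stands second highest of the three; compound 3 lies lower and compound 1 lies well higher, both gaps beyond the usual scatter. Compound 4 `COc1ccc2nc(C)cc(OCC(=O)Nc3nc(C)c(C)s3)c2c1` is not yet measured in this assay and differs from compound 2 at one place: 4,5-dimethyl-1,3-thiazol-2-yl in place of 3-methylphenyl on an amide-type nitrogen. Going by the values given here, no step between measured compounds isolates this change, so the direction rests on the change itself. A moderate decrease from compound 2 to compound 4 is expected, a number 0.63 log units lower from compound 2 to compound 4 (beyond the scatter), beyond the scatter but not large. Compound 4 is estimated at 4.2, likely between 3.6 and 4.8.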

Compound 4, distribution coefficient: 4.24
Compound 4: the middle estimate sits 0.04 log units below what was measured; measured number inside the range.
By their numbers in this assay, from the lowest: compounds 3 and 4 (each within the scatter of the next); then compound 2; then compound 1.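

In this assay the amide-type nitrogen now has its first single-place step: 4,5-dimethyl-1,3-thiazol-2-yl in place of 3-methylphenyl gives a number 0.59 log units lower from compound 2 to compound 4 (beyond the scatter) and counts as modest. The change keeps 7 heavy atoms at this place while exchanging a six-membered aromatic ring of carbon only for a five-membered aromatic ring with 2 hetero atoms. Nothing measured here accounts for the step.

This single step does not separate the ring change from the methyl groups. From the compounds shown here alone, how the number responds to an amine or a carboxylic acid on the ring at this nitrogen remains open.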